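The compounds below may be only part of what the source reports. "The series", "measured", "known", "first", "only" and "open" are said of these compounds alone.

Compound 1 `O=C1/C(=C/c2ccccc2F)CN(C(=S)SCc2cn(Cc3ccccc3Cl)nn2)C/C1=C\c1ccccc1F` was tested in a functional assay on DU-145 cells (Homo sapiens) for cytotoxicity, read by MTT assay, with a stated time of 24 h (on this read-out lower numbers stand for stronger inhibition and higher numbers for weaker inhibition), and gives 46300 nM. Compound 2 `O=C1/C(=C/c2ccccc2F)CN(C(=S)SCc2cn(Cc3ccccc3F)nn2)C/C1=C\c1ccccc1F` differs from it by fluoro in place of chloro on an aromatic carbon. For compound 2 this assay reports only a limit, > 80000 nM, not a number. The change from chloro to fluoro therefore made an at least 1.7-fold higher number from compound 1 to compound 2 (0.23 log units; that floor lies within the scatter), and the true size of that step is known only through (the limit of > 80000 nM in this assay, at which 1 of the 3 values shown sits).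

Compound 3 `COc1ccc(/C=C2\CN(Cc3cn(Cc4ccccc4Cl)nn3)C/C(=C\c3ccc(OC)cc3)C2=O)cc1` is built on another core; how the two cores differ is not broken down here. In this assay compound 3 gives 17800 nM, the lowest of the two numbers, with compound 1 as the nearest and that gap beyond the scatter.

Compound 4 `COc1ccc(/C=C2\CN(Cc3cn(Cc4ccccc4F)nn3)C/C(=C\c3ccc(OC)cc3)C2=O)cc1` has not yet been measured. It differs from compound 3 by fluoro in place of chloro on an aromatic carbon, the same change that turns compound 1 into compound 2, made at a place described in the same words. Since that change on the core of compound 1 gave a higher number, bounded only by the limit seen for compound 2, a comparable move is expected on the core of compound 3: the expected step is a 2.0-fold higher number from compound 3 to compound 4 (0.29 log units; within the scatter), resting on an at least 1.7-fold higher number from compound 1 to compound 2 (0.23 log units; that floor lies within the scatter). Compound 4 is accordingly expected to give 35000 nM in this assay, with the likely range running from 15000 nM to 80000 nM.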

Compound 4, half-maximal inhibitory concentration: 32600 nM
Estimate against measurement, compound 4: 1.1-fold (0.03 log units) above; the range from low to high includes it.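

On the core of compound 3, putting fluoro in place of chloro gives a 1.8-fold higher number from compound 3 to compound 4 (0.26 log units; within the scatter) in this assay. This step is a single readable number for the change, and it stays inside the usual scatter, as does the floor of the earlier step, so neither core gives firm evidence that the swap alters the result. The pair therefore does not show that the change carries over from one core to another with the same size, and it does not show that the size differs, because the earlier step rests on a limit rather than a number: the same change on two cores in this assay, an at least 1.7-fold higher number (0.23 log units; that floor lies within the scatter) from compound 1 to compound 2 and a 1.8-fold higher number (0.26 log units; within the scatter) from compound 3 to compound 4; the limit leaves it open whether they differ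

From the compounds shown here alone, how bromo, a nitrile or a plain hydrogen in place of chloro and fluoro on this aromatic carbon would read in this assay remains open on both cores, as does the effect of an amine or a carboxylic acid at that place. Going by these compounds, it also remains open which feature separating the core of compound 1 from the core of compound 3 would matter for this change, since the two cores are not related by a single difference.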